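The compounds below may be only part of what the source reports. "The series", "measured", "known", "first", "only" and "open" are said of these compounds alone.

Measured so far in an assay for inhibition of Dihydrofolate reductase (Gallus gallus); on this read-out higher numbers stand for weaker inhibition and lower numbers for stronger inhibition:
compound 1, `COCc1ccccc1Cc1cnc(N)nc1N`, gives 39800 nM
compound 2, `CCOc1ccccc1Cc1cnc(N)nc1N`, gives 24500 nM

Compound 2 carries the lower of the two numbers recorded in this assay; its nearest neighbour is compound 1, and the step of a 1.6-fold lower number from compound 1 to compound 2 (0.21 log units; within the scatter) is within the scatter, so the two compounds cannot be ordered against each other on this read-out.

Compound 3, `CS(=O)(=O)Oc1ccccc1Cc1cnc(N)nc1N`, has not yet been measured. Its difference from compound 2 is methylsulfonyl in place of ethyl on an oxygen on an aromatic ring; cut one bond further out, the change reads ethoxy to (methylsulfonyl)oxy. Within the data shown here, no measured step bears directly on an exchange at this oxygen: the one step available, a 1.6-fold lower number from compound 1 to compound 2 (0.21 log units; within the scatter), concerns a different change on the aromatic carbon and lies within the scatter. There is thus no shown precedent for a shift beyond the scatter in either direction, and the step to compound 3 is expected to be modest, a 1.4-fold higher number from compound 2 to compound 3 (0.15 log units; within the scatter).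

For compound 3 in this assay the estimate is 35000 nM, within a range of 10000 nM to 120000 nM; a wide range reflects the absence of any measured step of this kind.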

Compound 3, inhibition constant: 22900 nM
Compound 3: middle estimate off by 1.5-fold (0.18 log units), on the high side; the range from low to high includes it.
By their numbers in this assay, from the lowest: compounds 3, 2 and 1 (each within the scatter of the next).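

In this assay, among these compounds, the first change at this oxygen, methylsulfonyl in place of ethyl, gives a 1.1-fold lower number from compound 2 to compound 3 (0.03 log units; within the scatter) and the exchange on the aromatic carbon gives a 1.7-fold lower number from compound 1 to compound 3 (0.24 log units; within the scatter) so compound 3 cannot be ordered against either compound 2 or compound 1. The exchange is not a small one on paper: four heavy atoms enter for two, with two hydrogen-bond acceptors where ethyl has none and two double bonds outside aromatic rings, yet no shift beyond the scatter appears on this read-out. Nothing measured here accounts for that outcome.

Across the three compounds this position has therefore produced no difference that can be read, which says nothing yet about how far the read-out can move through changes made here. Open, on these data alone, is whether an amine on the aromatic carbon, a carboxylic acid, or a longer chain on the oxygen would give a number that stands clear of the scatter from those of compound 1, compound 2 and compound 3.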